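The source may report more compounds than this note shows. Statements on the series, on what has been measured and on what is new or still open speak of the compounds shown alone.

In a toxicity assay on Hepa-1c1c7 cells (Mus musculus) for inhibition (on this read-out lower numbers stand for stronger inhibition and higher numbers for weaker inhibition), compound 1 `CCCCC[C@@H](O)C#CC#CCO` gives > 100000 nM, which is a limit and not a number. Compound 2 `CCCCCC(O)C#CC#CCO` gives > 50000 nM, which is also a limit. Compound 3 `CCCCC[C@H](O)C#CC#CCO` departs from compound 2 in one respect: the two compounds have the same atoms and bonds; at least one stereo element is drawn with a configuration in one of them and without one in the other: 1 of 1 stereo elements differ; a stereocentre at a saturated chain carbon is drawn without a configuration in compound 2 and S in compound 3. For the measured compounds named here, the only measured step that bears on this change is a step that the two limits leave unreadable from compound 1 to compound 2, and it offers no readable size. With no size to carry over, the expected step that the limit leaves unreadable from compound 2 to compound 3 stays within the scatter, in no known direction. For compound 3 the estimate is 70000 nM, with an expected range from 25000 nM to 200000 nM.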

Compound 3, half-maximal inhibitory concentration: > 100000 nM
Compound 3 was reported as a limit (the forecaster's own chance of this, stated with the estimate: 80%); at least 1.4-fold (0.15 log units) between middle value and limit.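

No step can be read among compound 1, compound 2 and compound 3, whose results are all limits and not numbers. As far as these compounds go, whether the R or S configuration at the saturated chain carbon makes any difference in this assay stays open.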